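Series notes: benzothiazole in place of benzimidazole at compound 1

The compounds below may be only part of what the source reports. "The series", "measured", "known", "first", "only" and "open" are said of these compounds alone.

Measured in a functional assay on KB cells (Homo sapiens) for cytotoxicity, read by MTT assay, with a stated time of 48 h; a higher number here means a weaker inhibitor, a lower number a stronger inhibitor:
- compound 1 `CCn1cc(-c2nc3ccccc3[nH]2)c(=O)c2cc(F)c(N3CCNCC3)cc21`: 10500 nM
- compound 2 `CCn1cc(-c2nc3ccccc3[nH]2)c(=O)c2cc(F)c(N3CCN(C)CC3)cc21`: 36700 nM
- compound 3 `CCn1cc(-c2nc3ccccc3o2)c(=O)c2cc(F)c(N3CCN(C)CC3)cc21`: 87400 nM

Compound 1 gives the lowest number of the three in this assay. The nearest measured value lies a 3.5-fold higher number from compound 1 to compound 2 (0.54 log units; beyond the scatter), a change of methyl in place of hydrogen on an amine nitrogen in a ring. The furthest is compound 3, which gives 87400 nM where compound 1 gives 10500 nM.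

Compound 4 `CCn1cc(-c2nc3ccccc3s2)c(=O)c2cc(F)c(N3CCNCC3)cc21` is not yet measured. Its difference from compound 1: 1,3-benzothiazol-2-yl in place of 1H-benzimidazol-2-yl on an aromatic carbon. The step that bears on this is a 2.4-fold higher number from compound 2 to compound 3 (0.38 log units; beyond the scatter), where 1,3-benzoxazol-2-yl replaced 1H-benzimidazol-2-yl on the same aromatic carbon and the hydrogen-bond donor of the benzimidazole was lost. Among the measured compounds shown here, the present change also removes that donor, with a sulfur ring atom instead of oxygen, so a modest step toward a higher number in this assay is expected, with wide uncertainty as no sulfur analogue has been measured.

Compound 4 is therefore expected to give about 25000 nM, between 8000 nM and 80000 nM. The expected step is a 2.4-fold higher number from compound 1 to compound 4 (0.38 log units; beyond the scatter).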

Compound 4, half-maximal inhibitory concentration: 28700 nM
Compound 4: middle estimate off by 1.1-fold (0.06 log units), on the low side; the range from low to high includes it.
By their numbers in this assay, from the lowest: compound 1; then compounds 4 and 2 (each within the scatter of the next); then compound 3.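

In this assay, replacing 1H-benzimidazol-2-yl on this aromatic carbon with 1,3-benzothiazol-2-yl gives (a 2.7-fold higher number from compound 1 to compound 4 (0.44 log units; beyond the scatter)), so a second replacement at this place, now with a sulfur ring atom, moves the number in the same direction as the 1,3-benzoxazol-2-yl change, and none of the compounds shown goes against this. The direction also holds with hydrogen rather than methyl on the amine nitrogen in the ring, a setting that the step to the 1,3-benzoxazol-2-yl compound did not cover. Nothing available accounts for this step or shows what sets its size.

Going by these compounds, how 1,3-benzothiazol-2-yl and 1,3-benzoxazol-2-yl compare on an otherwise identical compound remains open. Also open, on these data alone, is how a carboxylic acid or an amide on this aromatic carbon would read in this assay.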